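This account rests on a few compounds, and the source may have more. Where it says the series, first, only, none or still open, it means among the compounds named here.

In a functional assay on K562 cells (Homo sapiens), read by MTT assay, with a stated time of 72 h (on this read-out lower numbers stand for stronger inhibition and higher numbers for weaker inhibition), compound 1 (`Nc1nc(N)c2c(-c3ccco3)cn([C@@H]3O[C@H](CO)[C@@H](O)[C@H]3O)c2n1`) gives > 20000 nM as a limit of the assay. Compound 2 (`Nc1nc(N)c2c(-c3cccs3)cn([C@@H]3O[C@H](CO)[C@@H](O)[C@H]3O)c2n1`) gives > 20000 nM as a limit too. Compound 3 (`Nc1nc(N)c2c(-c3ccsc3)cn([C@@H]3O[C@H](CO)[C@@H](O)[C@H]3O)c2n1`) likewise gives > 20000 nM as a limit, so it stands with the others (the limit of > 20000 nM in this assay, at which 3 of the 3 values shown sit). Compound 4 (`Nc1nc(N)c2c(-c3cc4ccccc4o3)cn([C@@H]3O[C@H](CO)[C@@H](O)[C@H]3O)c2n1`) differs from compound 3 in one group (1-benzofuran-2-yl in place of thiophen-3-yl on an aromatic carbon). Among the compounds with values here, the only measured steps exchange one five-membered aromatic ring for another (a step that the two limits leave unreadable from compound 1 to compound 2) and (a step that the two limits leave unreadable from compound 1 to compound 3) and (a step that the two limits leave unreadable from compound 2 to compound 3). None has a readable size, so no step beyond the scatter is expected in this assay in either direction. The expected step is small (a number no higher from compound 3 to compound 4 (the limit leaves the size open)). Compound 4 is estimated at 20000 nM with an expected range from 6000 nM to 40000 nM and may well return only a limit.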

Compound 4, half-maximal inhibitory concentration: > 20000 nM
Compound 4: a limit, no number (the forecaster's own chance of this, stated with the estimate: 75%); the middle value lies on the limit itself.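

Compound 4 returns only a limit, as compounds 1, 2 and 3 do, so no step among these four can be read in this assay: the limit of > 20000 nM in this assay, at which 4 of the 4 values shown sit.

The compounds shown leave open how strongly any of the four inhibits, and whether changing this aromatic group alters that at all.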